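A few compounds are considered here, and "the series" means these few. Any claim that something is new, unique, unknown or untested is made for them only; others in the source may bear on it.

In an ADME assay on cells (Hepatocyte, Mus musculus) for cytotoxicity, read by MTT assay, with a stated time of 24 h (on this read-out lower numbers stand for higher toxicity in this test and higher numbers for lower toxicity in this test), compound 1 (`O=S(=O)(c1ccccc1)n1c(-c2cn(-c3ccccc3)nc2-c2ccc(F)cc2)nc2ccccc21`) gives 231000 nM and compound 2 (`O=S(=O)(c1ccc(Cl)cc1)n1c(-c2cn(-c3ccccc3)nc2-c2ccc(F)cc2)nc2ccccc21`) gives 231000 nM, so compound 2 stands level with compound 1. Compound 3 (`O=S(=O)(c1ccc(Br)cc1)n1c(-c2cn(-c3ccccc3)nc2-c2ccc(F)cc2)nc2ccccc21`) carries bromo in place of chloro on an aromatic carbon, para to a large group: bromo in place of chloro on an aromatic carbon. Among the measured compounds shown here, the only measured step bearing on this change is no change at the digits printed from compound 1 to compound 2 (within the scatter), chloro in place of hydrogen on an aromatic carbon, and it lies within the scatter. No change beyond the scatter is therefore expected in this assay. The expected step is no change at the digits printed from compound 2 to compound 3 (within the scatter). For compound 3 the estimated value is 231000 nM, with an expected range of 120000 nM to 420000 nM.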

Compound 3, half-maximal cytotoxic concentration: > 300000 nM
Compound 3: a limit, no number; the forecaster's own chance of this, stated with the estimate: 15%; at least 1.2-fold (0.11 log units) between middle value and limit.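

In this assay compound 3 is read as a limit of the assay and not as a number: the limit of > 300000 nM in this assay, at which 1 of the 3 values shown sits. Bromo on this aromatic carbon, para to a large group, gives an at least 1.2-fold higher number from compound 2 to compound 3 (0.11 log units; that floor lies within the scatter), and set against hydrogen it gives an at least 1.2-fold higher number from compound 1 to compound 3 (0.11 log units; that floor lies within the scatter). From the compounds shown here alone, neither floor separates bromo from chloro or hydrogen at this position, and the true size of both steps stays unknown.

Still open, going by these compounds, is whether an amine or a carboxylic acid at this position would give a readable step in either direction.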